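A Small Change to the Amine Tail of Compound 2

The source may report more compounds than this note shows. Statements on the series, on what has been measured and on what is new or still open speak of the compounds shown alone.

compound 1 `CN(c1ccccc1)S(=O)(=O)c1ccc2c(c1)sc(=O)n2CCN1CCCC1`: 10%
compound 2 `CN(C)CCn1c(=O)sc2cc(S(=O)(=O)Nc3ccccc3)ccc21`: 21%

In an assay on HEK293 cells for displacement of a labelled ligand from 5-hydroxytryptamine receptor 6 (Homo sapiens), read by radioligand binding, with a stated time of 60 min, tested at 100 nM (on this read-out higher numbers stand for more inhibition at the one concentration tested (going by the name of the read-out) and lower numbers for less inhibition), compound 2 gives 21%, the higher of the two numbers shown, while compound 1 gives 10%, a gap beyond the usual scatter. Compound 3 `O=c1sc2cc(S(=O)(=O)Nc3ccccc3)ccc2n1CCN1CCCC1` has not yet been measured. It differs from compound 2 in one place: pyrrolidin-1-yl in place of dimethylamino on a saturated chain carbon, two bonds along the chain from an aromatic nitrogen. Within the data shown here, no measured pair shows exactly this change, so its size is unknown. Compound 1 also carries pyrrolidin-1-yl but differs from compound 3 elsewhere as well, so its value gives little guidance. The expected step is a number 1 percentage points lower from compound 2 to compound 3 (within the scatter), within the scatter. Compound 3 is estimated to give 20%, with a range from 5% to 40%.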

Compound 3, a percentage reported as inhibition, at one concentration (the size of the read-out at that concentration, not a potency): 37%
Estimate against measurement, compound 3: 17 percentage points below; low and high end bracket the measured number.
By their numbers in this assay, from the lowest: compound 1; then compound 2; then compound 3.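

In this assay, the step from dimethylamino to pyrrolidin-1-yl on the chain is a number 16 percentage points higher from compound 2 to compound 3 (beyond the scatter) and shows that this position is sensitive to the choice of amine. With pyrrolidin-1-yl held fixed, hydrogen in place of methyl on the sulfonamide nitrogen gives a number 27 percentage points higher from compound 1 to compound 3 (beyond the scatter) and shows that the sulfonamide nitrogen matters too. No measurement here explains either step.

Still open, going by these compounds, is whether a piperidin-1-yl or morpholin-4-yl group at the end of the chain would raise the number further. A longer chain between the aromatic nitrogen and the amine is equally untested in the compounds shown.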